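The source may hold more compounds than are shown below. What is called first, only, known or untested is meant among the compounds shown, and "the series" means these compounds.

Measured so far in a functional assay on NCI-H460 cells (Homo sapiens) for cytotoxicity, read by MTT assay, with a stated time of 72 h; on this read-out higher numbers stand for weaker inhibition and lower numbers for stronger inhibition:
compound 1 `CN(C)CCn1cnnc1-c1cc(Oc2ccc(NC(=O)N/N=C/c3ccc(Cl)cc3Cl)cc2F)ccn1` gives 130 nM
compound 2 `CN(C)CCn1cnnc1-c1cc(Oc2ccc(NC(=O)N/N=C/c3c(Cl)cccc3Cl)cc2F)ccn1` gives 350 nM
compound 3 `CN(C)CCn1cnnc1-c1cc(Oc2ccc(NC(=O)N/N=C/c3ccc(O)c(O)c3)cc2F)ccn1` gives 1930 nM

Compound 3 stands highest of the three numbers in this assay; the nearest measured neighbour is reached by a 5.5-fold higher number from compound 2 to compound 3 (0.74 log units; beyond the scatter) and the furthest by a 15-fold higher number from compound 1 to compound 3 (1.17 log units; beyond the scatter), both beyond the scatter.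

Compound 4 `CN(C)CCn1cnnc1-c1cc(Oc2ccc(NC(=O)N/N=C/c3cccc(Br)c3)cc2F)ccn1` differs from compound 3 by 3-bromophenyl in place of 3,4-dihydroxyphenyl on a carbon with a double bond to nitrogen. For the measured compounds named here, the steps that bear on this change are the two that run from a dichlorophenyl into the 3,4-dihydroxyphenyl, a 15-fold higher number from compound 1 to compound 3 (1.17 log units; beyond the scatter) and a 5.5-fold higher number from compound 2 to compound 3 (0.74 log units; beyond the scatter); both are beyond the scatter and both point toward higher numbers. Going by the values given here, the change to compound 4 runs the opposite way, from the dihydroxyphenyl to a halogen-bearing phenyl, though with a single bromine instead of two chlorines; the only measured step between two halogenated phenyls is a 2.7-fold higher number from compound 1 to compound 2 (0.43 log units; beyond the scatter), a modest one. A modest step toward lower numbers in this assay is therefore expected, a 5.5-fold lower number from compound 3 to compound 4 (0.74 log units; beyond the scatter). Compound 4 is expected to give about 350 nM in this assay, within a range of 120 nM to 1000 nM.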

Compound 4, half-maximal inhibitory concentration: 520 nM
Estimate against measurement, compound 4: 1.5-fold (0.17 log units) below; measured number inside the range.
By their numbers in this assay, from the lowest: compound 1; then compounds 2 and 4 (each within the scatter of the next); then compound 3.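

In this assay, the hydroxyl groups are not needed at this position, with a 3.7-fold lower number from compound 3 to compound 4 (0.57 log units; beyond the scatter) as 3-bromophenyl replaces 3,4-dihydroxyphenyl on the carbon with a double bond to nitrogen. A single bromine reads the same as two chlorines in one case, with a 1.5-fold higher number from compound 2 to compound 4 (0.17 log units; within the scatter) and the gap within the scatter, but not in the other, with a 4.0-fold higher number from compound 1 to compound 4 (0.60 log units; beyond the scatter) and the gap beyond it, so the number of halogens alone does not order the series: compound 2 goes against any such rule. Nothing available offers an explanation for these differences.

Still open, on these data alone, is whether one hydroxyl on the phenyl would match the 3,4-dihydroxyphenyl or the halogenated phenyls. Also open, as far as these compounds go, are how a 3-chlorophenyl would compare with the 3-bromophenyl, and how a phenyl carrying an amine or a methoxy group would read.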